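Notes on the aromatic amine substituent in a growth-inhibition series

The compounds below may be only part of what the source reports. "The series", "measured", "known", "first", "only" and "open" are said of these compounds alone.

Values from a functional assay on MDA-MB-231 cells (Homo sapiens) for inhibition, read by CCK-8 assay, with a stated time of 48 h (a higher number here means a weaker inhibitor of growth, a lower number a stronger inhibitor of growth), follow
- compound 1 `CN1CCN(c2ccc(Nc3ncc(Cl)c(NCc4ccc(C(F)(F)F)cc4)n3)nc2)CC1` gives 19100 nM
- compound 2 `CC(C)c1ccccc1Nc1nc(Nc2ccc(N3CCN(C)CC3)cn2)ncc1Cl` gives 4090 nM

Compound 2 has the lower of these two numbers. Compound 3 `COc1ccc(Nc2nc(Nc3ccc(N4CCN(C)CC4)cn3)ncc2Cl)cc1` carries 4-methoxyphenyl in place of 2-isopropylphenyl on a nitrogen on an aromatic ring. Going by the values given here, the only measured change at this place is a 4.7-fold lower number from compound 1 to compound 2 (0.67 log units; beyond the scatter) and this modest step involves a different pair of groups, so it sets no clear direction. The expected change in this assay is a 1.2-fold higher number from compound 2 to compound 3 (0.09 log units; within the scatter) and no step beyond the scatter is expected. Compound 3 is estimated at 5000 nM with 1800 nM to 15000 nM as its expected range.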

Compound 3, concentration for 50% growth inhibition: 8020 nM
Beside the measured number, compound 3's estimate is 1.6-fold (0.21 log units) below it; measured number inside the range.
By their numbers in this assay, from the lowest: compounds 2 and 3 (each within the scatter of the next); then compound 1.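

In this assay, 4-methoxyphenyl in place of 2-isopropylphenyl on this nitrogen gives a 2.0-fold higher number from compound 2 to compound 3 (0.29 log units; within the scatter), so these two substituted phenyl groups cannot be told apart here. Compound 3 also reads apart from the 4-(trifluoromethyl)benzyl compound, with a 2.4-fold lower number from compound 1 to compound 3 (0.38 log units; beyond the scatter), so both phenyl compounds now carry lower numbers than compound 1, though only modestly. No evidence is available to explain these numbers.

Still open, going by these compounds, is whether a carboxylic acid or a primary amine on the phenyl ring would move the number beyond the scatter. An unsubstituted benzyl group would also show whether the trifluoromethyl group contributes to the higher number of compound 1.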